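The compounds below may be only part of what the source reports. "The series", "measured", "known", "first", "only" and "open" are said of these compounds alone.

Compound 1 `Cn1c(=O)c(C(=O)NCCN)c(O)c2ccccc21` and compound 2 `Cn1c(=O)c(C(=O)NCCCCCCN)c(O)c2ccccc21` share one core and differ only in the chain on the amide-type nitrogen. In an assay on isolated protein for inhibition of seed linoleate 13S-lipoxygenase-1 (Glycine max), tested at 0.1 mM (a higher number here means more inhibition at the concentration tested (going by the name of the read-out), a lower number less inhibition), compound 1 gives 99.5%, while compound 2 gives 92.1%. The step of a number 7.4 percentage points lower from compound 1 to compound 2 (within the scatter), made with 4-aminobutyl in place of amino on a saturated chain carbon, two bonds along the chain from an amide-type nitrogen, changed nothing beyond the scatter. Compound 2 therefore holds the lower of the two numbers shown, but the gap to compound 1 is within the scatter. Compound 3 `Cn1c(=O)c(C(=O)Nc2ccccc2N)c(O)c2ccccc21` carries the change (2-aminophenyl in place of 6-aminohexyl on an amide-type nitrogen). Within the data shown here, only the step of a number 7.4 percentage points lower from compound 1 to compound 2 (within the scatter) bears on it, and that step was within the scatter; swapping a chain for an aromatic ring is a different kind of change, so no step beyond the scatter is firmly expected in either direction, with some room for a drop. Compound 3 is expected to give 85%, in a range from 55% to 100%, which would mean a step of a number 7.1 percentage points lower from compound 2 to compound 3 (within the scatter).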

Compound 3, a percentage reported as inhibition, at one concentration (the size of the read-out at that concentration, not a potency): 71.3%
Compound 3: middle estimate off by 13.7 percentage points, on the high side, within the range that was stated.
By their numbers in this assay, from the lowest: compound 3; then compounds 2 and 1 (each within the scatter of the next).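

Among the groups on this amide-type nitrogen, the aromatic ring is the first change to move the result beyond the scatter in this assay. Swapping the open chain for 2-aminophenyl gives a number 20.8 percentage points lower from compound 2 to compound 3 (beyond the scatter) and, against the shorter chain, a number 28.2 percentage points lower from compound 1 to compound 3 (beyond the scatter), whereas the chain change alone gave only a number 7.4 percentage points lower from compound 1 to compound 2 (within the scatter). Since 6-aminohexyl and 2-aminophenyl match in heavy atoms, hydrogen-bond donors and acceptors, the drop goes with the ring replacing the chain, and nothing at hand says why it occurs.

Still open, from the compounds shown here alone, is whether the aromatic ring alone accounts for the drop, which a plain phenyl or an aminocyclohexyl group on the same nitrogen would help to test. Equally open, going by these compounds, is whether the terminal amine matters at all, which a hexyl chain without an amine would address.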